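This account rests on a few compounds, and the source may have more. Where it says the series, first, only, none or still open, it means among the compounds named here.

Compound 1 is `CC(C)(C)C(=O)N1CCN(c2nc(=O)c3cc(C(F)(F)F)cc([N+](=O)[O-])c3s2)CC1`. In an ADME assay on Vero cells (Chlorocebus sabaeus) for cytotoxicity, read by MTT assay, with a stated time of 72 h (on this read-out lower numbers stand for higher toxicity in this test and higher numbers for lower toxicity in this test), compound 1 gives > 125000 nM, which is a limit of the assay and not a number.
Compound 2 is `O=C(c1cccc(F)c1)N1CCN(c2nc(=O)c3cc(C(F)(F)F)cc([N+](=O)[O-])c3s2)CC1`. In this assay compound 2 gives > 125000 nM, again a limit of the assay rather than a number.

On the numbers shown, compound 2 therefore stands only at a limit, and the one further value shown is likewise a limit. Compound 3, not yet measured, is `CC(C)CC(=O)N1CCN(c2nc(=O)c3cc(C(F)(F)F)cc([N+](=O)[O-])c3s2)CC1`; it differs from compound 2 by isobutyl in place of 3-fluorophenyl on a carbonyl carbon. Among the measured compounds shown here, the only measured step that bears on this change is a step that the two limits leave unreadable from compound 1 to compound 2, where a different group on the same carbonyl carbon was exchanged, and the limit of > 125000 nM in this assay, at which 2 of the 2 values shown sit, leaves its size unreadable. For the measured compounds named here, there is thus no measured step from which a direction or size could be taken, and no step beyond the scatter is expected in this assay for the exchange of a 3-fluorophenyl for an isobutyl on the carbonyl carbon. Compound 3 is accordingly expected to sit around 150000 nM, between 60000 nM and 400000 nM, which is an estimated step that the limit leaves unreadable from compound 2 to compound 3, most likely reported once more only as a limit.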

Compound 3, half-maximal cytotoxic concentration: > 125000 nM
Compound 3 ended at the assay's limit; the forecaster's own chance of this, stated with the estimate: 80%; the middle value is on the limit's open side.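

Compound 3 joins compound 1 and compound 2 in giving only a limit of the assay in this assay, so no step among compound 1, compound 2 and compound 3 can be read: the limit of > 125000 nM in this assay, at which 3 of the 3 values shown sit.

What these compounds leave open is whether tert-butyl, 3-fluorophenyl and isobutyl on the carbonyl carbon differ at all in this assay, and by how much.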